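This account rests on a few compounds, and the source may have more. Where it says the series, first, only, none or still open, it means among the compounds named here.

Compound 1 `O=C(O)COc1ccc(/C=C/C(=O)c2ccc(Cl)c(Cl)c2)cc1` was tested in a functional assay on MCF-12A cells (Homo sapiens) for inhibition (a higher number here means a weaker inhibitor, a lower number a stronger inhibitor), where compound 1 gives 28000 nM. Compound 2 `O=C(/C=C/c1ccc(B(O)O)cc1)c1ccc(Cl)c(Cl)c1` carries one change relative to compound 1: a group of 3 heavy atoms (1 boron, 2 oxygen; no ring) in place of a group of 5 heavy atoms (2 carbon, 3 oxygen; no ring), on an aromatic carbon. In this assay compound 2 gives 15000 nM, which amounts to a 1.9-fold lower number from compound 1 to compound 2 (0.27 log units; within the scatter). Compound 3 `O=C(O)COc1ccc(C(=O)/C=C/c2ccc(Cl)c(Cl)c2)cc1` is built from the same atoms as compound 1, joined in a different way; the difference between the two cores is not broken down here. In this assay compound 3 gives 15000 nM, the same at the digits shown as compound 2 and within the scatter of compound 1.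

Compound 4 `O=C(/C=C/c1ccc(Cl)c(Cl)c1)c1ccc(B(O)O)cc1` has not yet been measured. Going by the values given here, it differs from compound 3 by a group of 3 heavy atoms (1 boron, 2 oxygen; no ring) in place of a group of 5 heavy atoms (2 carbon, 3 oxygen; no ring), on an aromatic carbon, the same change at the same kind of place as the one that turns compound 1 into compound 2. The step is expected to be a 1.7-fold lower number from compound 3 to compound 4 (0.22 log units; within the scatter), close to the earlier one, because the same change gave a 1.9-fold lower number from compound 1 to compound 2 (0.27 log units; within the scatter). This rests on a single prior pair. Compound 4 is therefore estimated at 9000 nM in this assay, with a likely range from 4000 nM to 20000 nM.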

Compound 4, half-maximal inhibitory concentration: 11000 nM
Compound 4: middle estimate off by 1.2-fold (0.09 log units), on the low side; the range from low to high includes it.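

In this assay, putting the boron-bearing group in place of the carboxymethoxy group gives a 1.4-fold lower number from compound 3 to compound 4 (0.13 log units; within the scatter). Set beside the earlier step, the same change reads alike on the two cores, as far as repeated measurements of this kind can tell: the same change on two cores in this assay, a 1.9-fold lower number (0.27 log units; within the scatter) from compound 1 to compound 2 and a 1.4-fold lower number (0.13 log units; within the scatter) from compound 3 to compound 4, 1.4-fold (0.14 log units) apart, within the scatter of two such steps. Going by these compounds alone, neither step stands clear of the scatter on its own, so the agreement shows only that the change has no measurable effect on either core; it does not show a real gain in inhibition, and two cores are too few to predict how the change would behave on any other core.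

The compounds shown leave open whether a different group on this aromatic carbon, such as an amine, a nitrile or a longer chain, would move the number beyond the scatter. Also open, as far as these compounds go, is how the boron-bearing group would read on a core without the two chlorine atoms.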